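The source may report more compounds than this note shows. Statements on the series, on what has been measured and on what is new or still open speak of the compounds shown alone.

Measured in a physicochemical assay for lipophilicity, at pH 7.4; on this read-out lower numbers stand for lower lipophilicity and higher numbers for higher lipophilicity:
compound 1 `COc1cc(C)[nH]c(=O)c1CN1CCc2c(Cl)cc([C@@H](O)C3COC3)c(Cl)c2C1=O` gives 1.3;
compound 2 `COc1cc(C)[nH]c(=O)c1CN1CCc2c(Cl)cc([C@H](O)C3COC3)c(Cl)c2C1=O` gives 1.4;
compound 3 `COc1cc(C)[nH]c(=O)c1CN1CCc2c(Cl)cc(C(OC)C3(C)COC3)c(Cl)c2C1=O` gives 2.3; 2.2 (2 entries).

Compound 1 and compound 2 have the same atoms and bonds and differ only in how one stereocentre is drawn (the fact that compounds 1 and 2 differ only in the configuration as drawn); the step of a number 0.10 log units higher from compound 1 to compound 2 (within the scatter) lies within the scatter, so the two numbers cannot be told apart. Compound 3 has several entries the several entries of compound 3 in this assay, 2.3; 2.2 (2 entries) and no single number. Compound 4 `COc1cc(C)[nH]c(=O)c1CN1CCc2c(Cl)cc(-c3c(C)noc3C)c(Cl)c2C1=O` arises from compound 2 by the change (a group of 7 heavy atoms (5 carbon, 1 nitrogen, 1 oxygen; one five-membered aromatic ring with 2 hetero atoms) in place of a group of 6 heavy atoms (4 carbon, 2 oxygen; one four-membered non-aromatic ring with 1 hetero atom), on an aromatic carbon). For the measured compounds named here, the only measured step, a number 0.10 log units higher from compound 1 to compound 2 (within the scatter), concerns a change of configuration alone, so it does not bear on swapping one group for another. The numbers of compound 2 and compound 3 show compound 3 sitting higher. For compound 4 a rise a number 1.10 log units higher from compound 2 to compound 4 (beyond the scatter) in this assay is expected. Compound 4 is estimated at 2.5, within 2 to 3.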

Compound 4, distribution coefficient: 2.7
Compound 4: the middle estimate sits 0.20 log units below what was measured; measured number inside the range.
By their numbers in this assay, from the lowest: compounds 1 and 2 (each within the scatter of the next); then compound 4.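

At this aromatic carbon, putting 3,5-dimethyl-1,2-oxazol-4-yl in place of the group with the four-membered non-aromatic ring gives, in this assay, a number 1.30 log units higher from compound 2 to compound 4 (beyond the scatter) and a number 1.40 log units higher from compound 1 to compound 4 (beyond the scatter). A change of group at this position can therefore move the number far more than the change of configuration alone did. The swap gives a large rise from either starting compound: the fact that compounds 1 and 2 differ only in the configuration as drawn.

The two groups differ at once in ring, atoms and hydrogen-bond donors, and the compounds shown do not separate these. As far as these compounds go, how an amine or a carboxylic acid at this carbon would read in this assay remains open.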